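Methyl on the aromatic core: cytotoxicity notes

The source may report more compounds than this note shows. Statements on the series, on what has been measured and on what is new or still open speak of the compounds shown alone.

Measured compounds:
- compound 1 `O=C(O)c1c(O)cccc1C=Cc1ccc2ccccc2c1` — 97000 nM
- compound 2 `O=C(O)c1c(O)cc(Cl)cc1CCc1ccc2ccccc2c1` — 35000 nM
- compound 3 `CCN(CC)C(=O)c1c(CCc2ccc3ccccc3c2)cc(OC)cc1OC` — > 100000 nM

In an ADME assay on HEK293 cells (Homo sapiens) for cytotoxicity, read by resazurin assay, with a stated time of 24 h (a higher number here means that more compound is tolerated, a lower number that less compound is tolerated), compound 1 gives 97000 nM, the highest of the two numbers. Compound 2 sits at 35000 nM, a step beyond the usual scatter. For compound 3 the result is a limit of the assay, (the limit of > 100000 nM in this assay, at which 1 of the 3 values shown sits), not a number.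

The next compound, compound 4 `Cc1cc(O)c(C(=O)O)c(C=Cc2ccc3ccccc3c2)c1`, follows from compound 1 by a single change, methyl in place of hydrogen on an aromatic carbon. Going by the values given here, no measured pair shows this change, so no step of this kind has a known size. On the numbers in hand, a small methyl on the core is not expected to shift tolerance in this assay beyond the scatter, in either direction.

Compound 4 is therefore estimated at 90000 nM, within 40000 nM to 200000 nM. The expected step from compound 1 to compound 4 is a 1.1-fold lower number from compound 1 to compound 4 (0.03 log units; within the scatter), and a limit rather than a number is a real possibility.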

Compound 4, half-maximal cytotoxic concentration: 52000 nM
Compound 4: middle estimate off by 1.7-fold (0.24 log units), on the high side; low and high end bracket the measured number.
By their numbers in this assay, from the lowest: compounds 2, 4 and 1 (each within the scatter of the next, the first and the last beyond it). At a limit, above all of these: compound 3.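

Going by these compounds alone, compound 4 gives the first reading of this change: in this assay, methyl in place of hydrogen on an aromatic carbon, para to a carboxy group and meta to a hydroxy group, amounts to a 1.9-fold lower number from compound 1 to compound 4 (0.27 log units; within the scatter) and so does not separate the two compounds. At this position on the core of compound 1, the added carbon leaves tolerance within the usual scatter of repeated measurements. This rests on a single pair, and nothing measured here bears on a cause for the step.

Going by these compounds, whether a larger group at the same place, such as ethyl or trifluoromethyl, would also stay within the scatter remains open. Also open, on these data alone, is whether an amine or a chlorine there would give a step beyond it.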